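This account rests on a few compounds, and the source may have more. Where it says the series, first, only, none or still open, it means among the compounds named here.

Measured so far:
compound 1 `O=[N+]([O-])c1ccc(NC(=S)NCCNS(=O)(=O)c2ccc(-c3ccccc3OCc3ccccc3)s2)cc1` — 7100 nM
compound 2 `O=[N+]([O-])c1cccc(NC(=S)NCCNS(=O)(=O)c2ccc(-c3ccccc3OCc3ccccc3)s2)c1` — 12800 nM
compound 3 `COc1ccc(Oc2ccccc2-c2ccsc2S(=O)(=O)N2CCN(C(=O)Nc3cccc([N+](=O)[O-])c3)CC2)cc1OC` — > 50000 nM

In a functional assay on HeLa cells (Homo sapiens) for inhibition, read by CCK-8 assay, with a stated time of 48 h (a higher number here means a weaker inhibitor, a lower number a stronger inhibitor), compound 1 gives 7100 nM and compound 2 gives 12800 nM. Compound 3 reaches only a limit of this assay, > 50000 nM (the limit of > 50000 nM in this assay, at which 1 of the 3 values shown sits). Compound 4 `COc1ccc(Oc2ccccc2-c2ccsc2S(=O)(=O)N2CCN(C(=O)Nc3ccc([N+](=O)[O-])cc3)CC2)cc1OC` has not yet been measured in this assay. It differs from compound 3 by 4-nitrophenyl in place of 3-nitrophenyl on an amide-type nitrogen, and compound 1 differs from compound 2 by 4-nitrophenyl in place of 3-nitrophenyl on an amide-type nitrogen; these are the same kind of change, though the surroundings of the place differ, a thiocarbonyl carbon beside the nitrogen in the first pair and a carbonyl carbon in the second. The difference between the core of compound 2 and the core of compound 3 is not broken down here. The measured step is a 1.8-fold lower number from compound 2 to compound 1 (0.26 log units; within the scatter). The step from compound 3 to compound 4 is expected to be similar in size, a step that the limit leaves unreadable from compound 3 to compound 4, because the measured step of a 1.8-fold lower number from compound 2 to compound 1 (0.26 log units; within the scatter) was within the scatter. For compound 4 the estimated value is 60000 nM, with a range from 25000 nM to 150000 nM.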

Compound 4, half-maximal inhibitory concentration: > 50000 nM
Compound 4: a limit, no number; the forecaster's own chance of this, stated with the estimate: 75%; the middle value is on the limit's open side.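

No step can be read from compound 3 to compound 4, because both results are limits of the assay, not numbers: the limit of > 50000 nM in this assay, at which 2 of the 4 values shown sit.

Still open, on these data alone, is whether 4-nitrophenyl in place of 3-nitrophenyl changes the number at all on the core of compound 3.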